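A Methyl on the Piperidine Ring of Compound 3

A few compounds are considered here, and "the series" means these few. Any claim that something is new, unique, unknown or untested is made for them only; others in the source may bear on it.

Among the measured compounds shown here, compound 3 `COc1cc(COc2cc(N)c(Cl)cc2C(=O)CCCCN2CCCCC2)cc(OC)c1` is one of three compounds measured in a functional assay for antagonist activity at 5-hydroxytryptamine receptor 4 (Rattus norvegicus) (a higher number here means a more potent compound, by a factor of ten per unit of this negative logarithm, a lower number a less potent compound), where compound 3 gives 8.5. Compound 2 `COc1ccc(COc2cc(N)c(Cl)cc2C(=O)CCCCN2CCCCC2)cc1OC` gives 8.5 in this assay. The step of no change at the digits printed from compound 2 to compound 3 (within the scatter) lies within the scatter, so compound 3 stands level with compound 2. Compound 1 `CCOc1cc(N)c(Cl)cc1C(=O)CCCCN1CCCCC1` reaches only a limit of this assay; compound 1 gives < 7, and (the limit of < 7 in this assay, at which 1 of the 3 values shown sits). The steps of a number at least 1.50 log units higher from compound 1 to compound 2 (beyond the scatter) and a number at least 1.50 log units higher from compound 1 to compound 3 (beyond the scatter) are both large.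

Compound 4 `COc1cc(COc2cc(N)c(Cl)cc2C(=O)CCCCN2CCC(C)CC2)cc(OC)c1` differs from compound 3 in one place: methyl in place of hydrogen on a saturated ring carbon. None of the three measured steps touches this position; all three alter the group on the saturated chain carbon bound to the oxygen on the aromatic ring, which compound 3 and compound 4 hold in common. The measured steps therefore give no direct guide to the added methyl, and with the shared core and both ring substituents unchanged, no step beyond the scatter is expected in this assay. Compound 4 is thus estimated at 8.5, within 7.9 to 9.1. The expected step is no change at the digits printed from compound 3 to compound 4 (within the scatter); whether a methyl on the saturated ring carbon shifts the value at all is what the measurement will show.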

Compound 4, negative logarithm of the antagonist equilibrium constant: 8.3
Beside the measured number, compound 4's estimate is 0.20 log units above it; measured number inside the range.
By their numbers in this assay, from the lowest: compounds 4, 2 and 3 (each within the scatter of the next). At a limit, below all of these: compound 1.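

The methyl that turns piperidin-1-yl into 4-methylpiperidin-1-yl gives a number 0.20 log units lower from compound 3 to compound 4 (within the scatter) in this assay and is the first change shown at this ring, since all the earlier steps altered the group on the saturated chain carbon bound to an oxygen on an aromatic ring. The saturated ring carbon three ring bonds from the ring nitrogen therefore carries a methyl with compound 4 level with compound 3 within the scatter, whereas the steps at the chain carbon, such as a number at least 1.50 log units higher from compound 1 to compound 3 (beyond the scatter), are large, so in this pair the ring position registers nothing beyond the scatter. No measurement shown here bears on why the methyl leaves the value where it stands.

Going by these compounds, what stays open is whether a longer chain such as propyl, or a hydroxyl, an amine or a phenyl on this same ring carbon, would also stay within the scatter of compound 3 in this assay. Also open, on these data alone, is whether the methyl would read the same with the 3,4-dimethoxyphenyl group of compound 2 in place of the 3,5-dimethoxyphenyl group that compound 3 and compound 4 share.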